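The compounds below may be only part of what the source reports. "The series", "measured", "known", "first", "only" and "open" are said of these compounds alone.

Measured compounds:
- compound 1 `Cc1ccc2nc(NC(=O)CNC(=O)c3nn(-c4ccccc4)c(=O)c4ccccc34)sc2c1`: 35 nM
- compound 2 `COc1ccc(-n2nc(C(=O)NCC(=O)Nc3nc4ccc(C)cc4s3)c3ccccc3c2=O)cc1`: 25 nM
- compound 3 `CCOc1ccc(NC(=O)CSc2nc3c(c(=O)n2-c2ccccc2)SCC3)cc1`: 1000 nM

In an assay on L cells for inhibition of Protein-serine O-palmitoleoyltransferase porcupine (Mus musculus), read by reporter gene assay, with a stated time of 24 h (a lower number here means that less compound is needed, a higher number that more compound is needed for the effect), compound 1 gives 35 nM and stands second highest of the three numbers. Compound 2 gives 25 nM, and the step of a 1.4-fold lower number from compound 1 to compound 2 (0.15 log units; within the scatter) lies within the scatter. Compound 3, on a different core, gives 1000 nM, a higher number than compound 1 and beyond the scatter.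

Compound 4 `O=C(CNC(=O)c1nn(-c2ccccc2)c(=O)c2ccccc12)Nc1nc2ccc([N+](=O)[O-])cc2s1` differs from compound 1 in one place: nitro in place of methyl on an aromatic carbon, that is, 6-methyl-1,3-benzothiazol-2-yl becomes 6-nitro-1,3-benzothiazol-2-yl. Going by the values given here, no measured step swaps methyl for nitro, and the only single-point step on this core is the change from compound 1 to compound 2, which replaces hydrogen with methoxy on another ring and stays within the scatter. The account therefore expects a step of a 1.7-fold higher number from compound 1 to compound 4 (0.23 log units; within the scatter) in this assay, of modest size and uncertain direction, with a slightly higher number held most likely. Compound 4 is estimated at 60 nM, within a range from 15 nM to 300 nM.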

Compound 4, half-maximal effective concentration: 240 nM
Beside the measured number, compound 4's estimate is 4.0-fold (0.60 log units) below it, within the range that was stated.
By their numbers in this assay, from the lowest: compounds 2 and 1 (each within the scatter of the next); then compound 4; then compound 3.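

In this assay, the change from 6-methyl-1,3-benzothiazol-2-yl to 6-nitro-1,3-benzothiazol-2-yl gives a 6.9-fold higher number from compound 1 to compound 4 (0.84 log units; beyond the scatter). This shows that the number responds to the group carried at this position on the six-membered aromatic ring of carbon only. Going by these compounds alone, the earlier single-place change on the shared core, on another ring, gave only a 1.4-fold lower number from compound 1 to compound 2 (0.15 log units; within the scatter), which lies within the scatter, so this is the first step on the core that lies beyond it.

The compounds shown leave open how an amine, a chlorine or a longer alkyl chain at this position would read, and whether the step would hold with the methoxy of compound 2 in place. No measurement shown here bears on what lies behind the step.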